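The compounds below may be only part of what the source reports. "The series", "measured", "known", "first", "only" and "open" are said of these compounds alone.

In a physicochemical assay for solubility (a lower number here means a less soluble compound, a higher number a more soluble compound), the measured compounds read as follows:

Compound 1 `N#Cc1cccc(S(=O)(=O)N2CCC(NS(=O)(=O)c3cc(S(=O)(=O)c4ccccc4)ccc3C(F)(F)F)CC2)c1` gives 6300 nM
Compound 2 `O=C(O)CCCC(=O)N1CCC(NS(=O)(=O)c2cc(S(=O)(=O)c3ccccc3)ccc2C(F)(F)F)CC1` gives 50000 nM
Compound 3 `CC(C)(C)OC(=O)N1CC[C@H](C(=O)N2CCC(NS(=O)(=O)c3cc(S(=O)(=O)c4ccccc4)ccc3C(F)(F)F)CC2)C1` gives 25000 nM

Compound 3 lies within the scatter of compound 2, and both read higher than compound 1. Compound 4 `O=C(C1CCNCC1)N1CCC(NS(=O)(=O)c2cc(S(=O)(=O)c3ccccc3)ccc2C(F)(F)F)CC1` carries piperidin-4-yl in place of 1-(tert-butoxycarbonyl)pyrrolidin-3-yl on a carbonyl carbon. With a 2.0-fold lower number from compound 2 to compound 3 (0.30 log units; within the scatter) on that same kind of carbon, no step beyond the scatter is expected in this assay for this change, although a 7.9-fold higher number from compound 1 to compound 2 (0.90 log units; beyond the scatter) on an amine nitrogen in a ring shows that larger steps occur among these compounds. The estimated step is a 1.2-fold higher number from compound 3 to compound 4 (0.08 log units; within the scatter) on this reasoning. The estimate for compound 4 is 30000 nM (expected range 12000 nM to 75000 nM).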

Compound 4, solubility: 100000 nM
Estimate against measurement, compound 4: 3.3-fold (0.52 log units) below, outside the stated range (above it).
By their numbers in this assay, from the lowest: compound 1; then compounds 3, 2 and 4 (each within the scatter of the next, the first and the last beyond it).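

In this assay, the carbonyl carbon on the amide-type nitrogen in a ring shows its first step beyond the scatter: piperidin-4-yl in place of 1-(tert-butoxycarbonyl)pyrrolidin-3-yl gives a 4.0-fold higher number from compound 3 to compound 4 (0.60 log units; beyond the scatter) at this place. Piperidin-4-yl in place of 3-carboxypropyl gives a 2.0-fold higher number from compound 2 to compound 4 (0.30 log units; within the scatter), while (piperidin-4-yl)carbonyl in place of (3-cyanophenyl)sulfonyl on the amine nitrogen in a ring gives a 16-fold higher number from compound 1 to compound 4 (1.20 log units; beyond the scatter) as the largest step shown. No measured evidence accounts for these steps.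

As far as these compounds go, whether an open-chain amine such as 2-aminoethyl on this carbonyl carbon would read like compound 4 remains open.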